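The compounds below may be only part of what the source reports. "The series", "measured", "known", "first", "only" and "open" are said of these compounds alone.

Measured so far in a functional assay on SMMC-7721 cells (Homo sapiens) for cytotoxicity, read by MTT assay, with a stated time of 72 h; on this read-out higher numbers stand for weaker inhibition and lower numbers for stronger inhibition:

compound 1 `COc1cc(C=C2C(=O)N(c3ccc(Cl)cc3)N(c3ccc(Cl)cc3)C2=O)ccc1O` — 64900 nM
compound 2 `COc1cccc(C=C2C(=O)N(c3ccc(Cl)cc3)N(c3ccc(Cl)cc3)C2=O)c1OC` — 14100 nM

Going by the values given here, compound 2 gives the lowest number of the two; the only neighbour is compound 1, which sits higher by a 4.6-fold lower number from compound 1 to compound 2 (0.66 log units; beyond the scatter). That single step is the whole body of evidence on this series.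

The next compound is compound 3 `O=C1C(=C/C=C/c2ccccc2)C(=O)N(c2ccc(Cl)cc2)N1c1ccc(Cl)cc1`. It differs from compound 2 as follows: 2-phenylethenyl in place of 2,3-dimethoxyphenyl on a double-bonded chain carbon bound to a double-bonded ring carbon. Among the compounds with values here, no measured step bears directly on this change. Within the data shown here, the one step known, a 4.6-fold lower number from compound 1 to compound 2 (0.66 log units; beyond the scatter), concerns a rearrangement of oxygen substituents on the aryl group and says little about removing the aryl group's substituents altogether and inserting a 2-phenylethenyl in its place. Among the measured compounds shown here, with no step of that kind in hand, the expectation has to be anchored on compound 2 itself, with a wide range and no clear direction.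

Compound 3 is therefore expected to land near compound 2, estimated at 15000 nM (range 5000 nM to 45000 nM). This estimate means a step of a 1.1-fold higher number from compound 2 to compound 3 (0.03 log units; within the scatter) in this assay, which is within the scatter.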

Compound 3, half-maximal inhibitory concentration: 10100 nM
The estimate for compound 3 lay 1.5-fold (0.17 log units) above the measured number; measured number inside the range.
By their numbers in this assay, from the lowest: compounds 3 and 2 (each within the scatter of the next); then compound 1.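

In this assay, the position on a double-bonded chain carbon bound to a double-bonded ring carbon accepts 2-phenylethenyl in place of 2,3-dimethoxyphenyl with no readable shift (a 1.4-fold lower number from compound 2 to compound 3 (0.14 log units; within the scatter)), so in this pair neither oxygen substituent of the leaving group is needed to keep the number at this level, and an added double bond outside aromatic rings is accepted there. The same exchange made against 4-hydroxy-3-methoxyphenyl gives a modest gain (a 6.4-fold lower number from compound 1 to compound 3 (0.81 log units; beyond the scatter)), which leaves compound 1 as the weakest of the three, with two different groups at this position giving numbers within the scatter of each other and only the 4-hydroxy-3-methoxyphenyl compound standing apart. No measurement on hand accounts for either step.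

Still open, on these data alone, is whether a longer chain carrying a further double bond between the core and the phenyl ring would hold the number or move it beyond the scatter. Equally open is how an amine or a carboxylic acid on the phenyl ring of 2-phenylethenyl would behave at this position, since the three compounds shown carry only methoxy and hydroxy substituents there.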